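Swapping the aryl group on the amine nitrogen

The source may hold more compounds than are shown below. What is called first, only, known or untested is meant among the compounds shown, and "the series" means these compounds.

In a functional assay on MGC-803 cells (Homo sapiens) for inhibition, read by sulforhodamine B assay (on this read-out higher numbers stand for weaker inhibition and lower numbers for stronger inhibition), compound 1 (`O=C1C=C(NC2CCCC2)C(=O)c2c1nc1n2[C@H]2OC[C@@H](O)[C@H]2OC1`) gives > 8000 nM, which is a limit. Within the data shown here, compound 2 (`O=C1C=C(Nc2ccc(C(F)(F)F)cc2)C(=O)c2c1nc1n2[C@H]2OC[C@@H](O)[C@H]2OC1`) gives 2820 nM, the only actual number so far. Compound 3 (`Cc1ccc(NC2=CC(=O)c3nc4n(c3C2=O)[C@H]2OC[C@@H](O)[C@H]2OC4)cc1C`) differs from compound 2 by 3,4-dimethylphenyl in place of 4-(trifluoromethyl)phenyl on an amine nitrogen. Among the measured compounds shown here, the sole measured step, an at least 2.8-fold lower number from compound 1 to compound 2 (0.45 log units; beyond the scatter), replaced cyclopentyl with an aromatic ring, whereas this change keeps one, so it offers only a weak guide. No step beyond the scatter is therefore expected in this assay, and the expected step is a 1.1-fold higher number from compound 2 to compound 3 (0.03 log units; within the scatter). For compound 3 the estimated value is 3000 nM, with an expected range of 1200 nM to 7500 nM.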

Compound 3, half-maximal inhibitory concentration: 860 nM
For compound 3 the middle estimate is 3.5-fold (0.54 log units) above the measured one, outside the stated range (below it).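

In this assay, the choice among aromatic groups on the amine nitrogen matters, which compound 1 and compound 2 alone did not show: 3,4-dimethylphenyl in place of 4-(trifluoromethyl)phenyl gives a 3.3-fold lower number from compound 2 to compound 3 (0.52 log units; beyond the scatter). Replacing cyclopentyl with 3,4-dimethylphenyl gives an at least 9.3-fold lower number from compound 1 to compound 3 (0.96 log units; beyond the scatter). That step is only a bound: the limit of > 8000 nM in this assay, at which 1 of the 3 values shown sits.

Which of the two methyl groups carries the step remains open, as the shown compounds include no phenyl ring with a single methyl group. On these data alone, how a methoxy group or a chlorine on the phenyl ring would read at this nitrogen also remains open.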